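From compound 3 to compound 4: losing an ethoxy group

The source may report more compounds than this note shows. Statements on the series, on what has been measured and on what is new or still open speak of the compounds shown alone.

In a functional assay, read by spectrophotometry, with a stated time of 5 min (a lower number here means a stronger inhibitor, a higher number a weaker inhibitor), compound 1 `CCOc1cc(/C=C/C(=O)C(=Cc2ccc(O)c(OC)c2)C(=O)/C=C/c2ccc(O)c(OCC)c2)ccc1O` reads 60500000 nM and compound 2 `CCOc1cc(/C=C/C(=O)C(=Cc2ccc(OC)c(OC)c2)C(=O)/C=C/c2ccc(O)c(OCC)c2)ccc1O` reads 53200000 nM while compound 3 `CCOc1cc(C=C(C(=O)/C=C/c2ccc(O)c(OCC)c2)C(=O)/C=C/c2ccc(O)c(OCC)c2)ccc1O` reads 96700000 nM so that compound 3 stands within the scatter of both. Compound 4 `CCOc1cc(/C=C/C(=O)C(=Cc2ccc(O)cc2)C(=O)/C=C/c2ccc(O)c(OCC)c2)ccc1O` differs from compound 3 at one place hydrogen in place of ethoxy on an aromatic carbon with hydrogen in place of ethoxy on an aromatic carbon, ortho to a hydroxy group, turning 3-ethoxy-4-hydroxyphenyl into 4-hydroxyphenyl.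

For the measured compounds named here, no measured step removes that ethoxy outright, so the evidence is indirect. The closest is a 1.6-fold higher number from compound 1 to compound 3 (0.20 log units; within the scatter) for methyl in place of hydrogen on a saturated chain carbon bound to an oxygen on an aromatic ring. Next come a 1.8-fold higher number from compound 2 to compound 3 (0.26 log units; within the scatter) for 3-ethoxy-4-hydroxyphenyl in place of 3,4-dimethoxyphenyl and a 1.1-fold lower number from compound 1 to compound 2 (0.06 log units; within the scatter) for methyl in place of hydrogen on an oxygen on an aromatic ring. Going by these compounds, all three edit the arm that changes in compound 4, and on that record no step beyond the scatter is expected in this assay here, although the full loss of the group remains untested. The step expected is a 1.3-fold lower number from compound 3 to compound 4 (0.11 log units; within the scatter) on this estimate. Compound 4 is estimated at 75000000 nM with a range of 35000000 nM to 160000000 nM as the expected span.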

Compound 4, half-maximal inhibitory concentration: 48000000 nM
The estimate for compound 4 lay 1.6-fold (0.19 log units) above the measured number, within the range that was stated.
By their numbers in this assay, from the lowest: compounds 4, 2, 1 and 3 (each within the scatter of the next).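

In this assay, for the compounds shown here, taking the ethoxy group off the aromatic carbon ortho to a hydroxy group, which turns 3-ethoxy-4-hydroxyphenyl into 4-hydroxyphenyl, gives a 2.0-fold lower number from compound 3 to compound 4 (0.30 log units; within the scatter) and so shows that even the full loss of this group, rather than the smaller edits of the earlier compounds, does not carry the number past the scatter. The two other routes to the same arm agree, with hydrogen in place of methoxy giving a 1.3-fold lower number from compound 1 to compound 4 (0.10 log units; within the scatter) and 4-hydroxyphenyl in place of 3,4-dimethoxyphenyl giving a 1.1-fold lower number from compound 2 to compound 4 (0.04 log units; within the scatter), so that among these four compounds ethoxy, methoxy and hydrogen at this position are not separated from one another. Nothing measured here offers an explanation for this result.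

The compounds shown leave open whether any group at this aromatic carbon can move the number beyond the scatter, since only ethoxy, methoxy and hydrogen appear there. An amine, a carboxylic acid or a longer chain such as butoxy at the same place would test that, and the answer cannot be inferred from these four compounds.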